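A few compounds are considered here, and "the series" means these few. Any claim that something is new, unique, unknown or untested is made for them only; others in the source may bear on it.

Three compounds have been measured in an assay on cells for inhibition of Rho-associated protein kinase 2 (Homo sapiens), read by radiometric assay and 33P incorporation, in the presence of a further agent that is not named here; a lower number here means a stronger inhibitor, a higher number a weaker inhibitor:
compound 1 `CC(C)OC(=O)c1cccc(NC(=O)c2cccc(-c3cc(C(=O)Nc4ccncc4F)ccc3CN)c2)c1` gives 7 nM
compound 2 `NCc1ccc(C(=O)Nc2ccncc2F)cc1-c1cccc(C(=O)Nc2ccc(CC(=O)O)cc2)c1` gives 1.8 nM
compound 3 `COCCOC(=O)c1ccc(F)c(C(=O)Nc2cccc(-c3cc(C(=O)Nc4ccncc4F)ccc3CN)c2)c1` gives < 1 nM, which is a limit of the assay and not a number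

Compound 3 therefore stands at the strong edge of what this assay reports; its value is the limit of < 1 nM in this assay, at which 1 of the 3 values shown sits, so its true position cannot be read more finely than that.

Compound 4 `NCc1ccc(C(=O)Nc2ccncc2F)cc1-c1cccc(NC(=O)c2cc(C(=O)O)ccc2F)c1` is drawn from compound 3 by one change: hydrogen in place of 2-methoxyethyl on an oxygen next to a carbonyl group. Within the data shown here, the only measured step that touches an ester turned into an acid is a 3.9-fold lower number from compound 1 to compound 2 (0.59 log units; beyond the scatter), which placed 4-(carboxymethyl)phenyl in place of 3-(isopropoxycarbonyl)phenyl on an amide-type nitrogen. Among the measured compounds shown here, that change is not the same as the one from compound 3 to compound 4, but both exchange an ester for a carboxy group, and the measured case moved in the stronger direction by a modest amount.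

Compound 4 is thus expected to sit at or beyond the limit that compound 3 reaches, with a step that the limit leaves unreadable from compound 3 to compound 4 that is estimated to be small or within the scatter. Compound 4 is estimated at 0.7 nM, within 0.25 nM to 2 nM, and a limit rather than a number is a real possibility.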

Compound 4, half-maximal inhibitory concentration: < 1 nM
Compound 4: a limit, no number; the forecaster's own chance of this, stated with the estimate: 55%; the middle value does not contradict the limit.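

Compound 4 gives < 1 nM, which is a limit of the assay and not a number. Compound 3 stands at the same limit, so no step can be read between these two compounds: the limit of < 1 nM in this assay, at which 2 of the 4 values shown sit.

The compounds shown leave open whether (2-methoxyethoxy)carbonyl in compound 3 and carboxy in compound 4 differ in strength of inhibition at all, and by how much.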